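Amine substitution on the sulfonamide side chain: solubility notes

The compounds below may be only part of what the source reports. "The series", "measured", "known", "first", "only" and "open" are said of these compounds alone.

Among the compounds with values here, in a physicochemical assay for solubility, read by HPLC (a higher number here means a more soluble compound, a lower number a less soluble compound), compound 3 `Cc1ncc([N+](=O)[O-])n1CCS(=O)(=O)NCCN(C)C` gives 46800000 nM, the lower of the two numbers so far, with compound 1 `O=C(O)CCNS(=O)(=O)Cn1ccnc1[N+](=O)[O-]` nearest at 72100000 nM, a gap within the scatter. Compound 2 `Cc1ncc([N+](=O)[O-])n1CCS(=O)(=O)NCCO` is reported only as a limit of this assay, > 49300000 nM. That point is the limit of > 49300000 nM in this assay, at which 1 of the 3 values shown sits. Within the data shown here, the single measured step at this position, an at least 1.0-fold lower number from compound 2 to compound 3 (0.02 log units; that floor lies within the scatter), stays within the scatter. Compound 4 `CCN(CC)CCNS(=O)(=O)CCn1c([N+](=O)[O-])cnc1C` differs from compound 3 by diethylamino in place of dimethylamino on a saturated chain carbon, two bonds along the chain from a sulfonamide nitrogen. Among the measured compounds shown here, no measured step alters the alkyl groups on this amine, and the one step touching this chain position was flat, so in this assay the expected step is a 1.2-fold lower number from compound 3 to compound 4 (0.07 log units; within the scatter), none beyond the scatter. Compound 4 is therefore estimated at 40000000 nM, within 18000000 nM to 85000000 nM.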

Compound 4, solubility: 45700000 nM
Compound 4: the middle estimate sits 1.1-fold (0.06 log units) below what was measured; low and high end bracket the measured number.
By their numbers in this assay, from the lowest: compounds 4, 3 and 1 (each within the scatter of the next).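

In this assay, within the data shown here, the one step on the alkyl groups of this amine is a 1.0-fold lower number from compound 3 to compound 4 (0.01 log units; within the scatter) and so diethylamino and dimethylamino cannot be told apart at this position, despite the larger group. Against a limit, diethylamino in place of hydroxy gives only an at least 1.0-fold lower number from compound 2 to compound 4 (0.03 log units; that floor lies within the scatter) as a floor: the limit of > 49300000 nM in this assay, at which 1 of the 4 values shown sits.

Open, from the compounds shown here alone, is whether a ring amine such as morpholine or piperidine, or a longer chain carrying the amine, would leave the number within the scatter. Going by these compounds, the size of any step from the hydroxy compound also stays open.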